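The source may hold more compounds than are shown below. What is called first, only, known or untested is meant among the compounds shown, and "the series" means these compounds.

Compound 2 `CNS(=O)(=O)c1ccc(C)c(C#Cc2cc(Cl)ccc2OCC(=O)O)c1` gives 10 nM in an assay on CHO cells for displacement of a labelled ligand from prostaglandin D2 receptor 2 (Homo sapiens), read by scintillation counting; on this read-out higher numbers stand for weaker inhibition and lower numbers for stronger inhibition. Compound 1 `Cc1ccc(S(=O)(=O)CCO)cc1C#Cc1cc(Cl)ccc1OCC(=O)O` gives 19 nM in this assay.

Compound 2 has the lower of the two numbers, but the gap between them is a 1.9-fold lower number from compound 1 to compound 2 (0.28 log units; within the scatter), so the two stand together. Compound 3 `Cc1ccc(S(=O)(=O)N(C)CCCN(C)C)cc1C#Cc1cc(Cl)ccc1OCC(=O)O` differs from compound 2 by 3-(dimethylamino)propyl in place of hydrogen on a sulfonamide nitrogen. Within the data shown here, no measured step touches this nitrogen; the only step known, from compound 1 to compound 2, changed the group on the sulfonyl sulfur and was a 1.9-fold lower number from compound 1 to compound 2 (0.28 log units; within the scatter), so variation around the sulfonyl group has so far moved little. For compound 3 a step of a 1.5-fold higher number from compound 2 to compound 3 (0.18 log units; within the scatter) is therefore expected, nothing beyond the scatter. The estimate for compound 3 is 15 nM, within 5 nM to 50 nM.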

Compound 3, inhibition constant: 287 nM
Beside the measured number, compound 3's estimate is 19-fold (1.28 log units) below it, and the stated range ends below it.
By their numbers in this assay, from the lowest: compounds 2 and 1 (each within the scatter of the next); then compound 3.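

Variation around the sulfonyl group is no longer harmless: 3-(dimethylamino)propyl on the sulfonamide nitrogen gives a 29-fold higher number from compound 2 to compound 3 (1.46 log units; beyond the scatter). Set against the 2-hydroxyethyl group on the sulfonyl sulfur, the same large rise appears, with a 15-fold higher number from compound 1 to compound 3 (1.18 log units; beyond the scatter), so this substituent weakens inhibition clearly in both comparisons. Nothing available explains the rise.

Still open, as far as these compounds go, is whether the rise follows the chain itself or its dimethylamino end. An ethyl or a plain propyl group on this nitrogen, or a propyl chain ending in a hydroxyl group or a carboxylic acid, would separate the two.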